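Swapping the five-membered ring on the carbonyl of compound 2

This account rests on a few compounds, and the source may have more. Where it says the series, first, only, none or still open, it means among the compounds named here.

Of the compounds shown here, two built on the same core have been tested in a functional assay on SK-BR-3 cells (Homo sapiens) for antiproliferative activity, read by XTT assay, with a stated time of 72 h; on this read-out lower numbers stand for stronger inhibition and higher numbers for weaker inhibition. Compound 1 `COc1ccc(-c2cc3ccccc3nc2/C=C/C(=O)c2ccc(OC)c(OC)c2)cc1` gives 3260 nM in this assay. Compound 2 `COc1ccc(-c2cc3ccccc3nc2/C=C/C(=O)c2ccco2)cc1` gives 640 nM in this assay, and this is the lowest of the two numbers, with the step of a 5.1-fold lower number from compound 1 to compound 2 (0.71 log units; beyond the scatter) lying beyond the usual scatter. Compound 3 `COc1ccc(-c2cc3ccccc3nc2/C=C/C(=O)c2ccc(Br)s2)cc1` has not yet been measured. It differs from compound 2 in one place: 5-bromothiophen-2-yl in place of furan-2-yl on a carbonyl carbon. Going by the values given here, the only measured step that touches this position is a 5.1-fold lower number from compound 1 to compound 2 (0.71 log units; beyond the scatter), where a six-membered ring with two methoxy groups gave way to a five-membered aromatic ring with one hetero atom. The change to compound 3 keeps a five-membered aromatic ring with one hetero atom on the carbonyl, so a smaller shift than that step seems likely, and a result within the scatter would not surprise. The expectation for compound 3 in this assay is 550 nM, with a range from 220 nM to 1400 nM, which as a step means a 1.2-fold lower number from compound 2 to compound 3 (0.07 log units; within the scatter).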

Compound 3, half-maximal inhibitory concentration: 520 nM
Compound 3: the middle estimate sits 1.1-fold (0.02 log units) above what was measured, within the range that was stated.
By their numbers in this assay, from the lowest: compounds 3 and 2 (each within the scatter of the next); then compound 1.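

In this assay the change from furan-2-yl to 5-bromothiophen-2-yl on the carbonyl carbon gives a 1.2-fold lower number from compound 2 to compound 3 (0.09 log units; within the scatter) and so leaves no readable difference, which shows that this position accepts a sulfur-containing ring carrying a bromine as readily as the smaller oxygen-containing ring. Replacing the 3,4-dimethoxyphenyl group with this same brominated ring gives a 6.3-fold lower number from compound 1 to compound 3 (0.80 log units; beyond the scatter) and thereby shows that the gain seen earlier with furan-2-yl is not confined to that one ring, since two different five-membered aromatic rings now stand apart from the six-membered ring of compound 1. No measurement here explains how these groups act on the cells.

As far as these compounds go, the sulfur and the bromine enter together, so their separate contributions stay unknown, and a plain thiophen-2-yl group or a 5-bromofuran-2-yl group would be needed to tell them apart. Also open, from the compounds shown here alone, is whether this position needs an aromatic ring at all, or whether a cyclohexyl ring, a propyl chain or a five-membered ring carrying an amine would serve equally well.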